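The source may hold more compounds than are shown below. What is called first, only, known or untested is meant among the compounds shown, and "the series" means these compounds.

Measured so far:
- compound 1 `COc1cc(/C=C2\CCC/C(=C\c3ccccc3[N+](=O)[O-])C2=O)cc(OC)c1OC`: 4.86
- compound 2 `Cc1ccc(/C=C2\CCC/C(=C\c3cccc([N+](=O)[O-])c3)C2=O)cc1`: 5.06

Both numbers come from a physicochemical assay for lipophilicity; on this read-out lower numbers stand for lower lipophilicity and higher numbers for higher lipophilicity. Going by the values given here, compound 1 stands at the lower of the two values in this assay, with compound 2 the nearest and only neighbour; the gap between them lies within the usual scatter, so the pair gives no order and no measured step. Among the compounds with values here, no two measured compounds differ in a single place, and no measured step of any kind is available for guidance.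

Compound 3 `COc1cc(/C=C2\CCC/C(=C\c3ccc([N+](=O)[O-])cc3)C2=O)cc(OC)c1OC` has not yet been measured. It differs from compound 1 in one respect: 4-nitrophenyl in place of 2-nitrophenyl on a double-bonded chain carbon bound to a double-bonded ring carbon. The two have the same atoms, joined differently; the nitro group is kept and the trimethoxyphenyl side of the shared core is untouched. With nothing measured to anchor such a change, the expectation in this assay is a step of no more than the scatter, with a slight lean upward rather than downward. Compound 3 is therefore estimated at 5, with a range from 4.6 to 5.4. The expected step of a number 0.14 log units higher from compound 1 to compound 3 (within the scatter) is small and within the scatter.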

Compound 3, partition coefficient: 5.08
Compound 3: the middle estimate sits 0.08 log units below what was measured; the measured number falls inside the stated range.
By their numbers in this assay, from the lowest: compounds 1, 2 and 3 (each within the scatter of the next).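

In this assay, going by these compounds alone, 4-nitrophenyl in place of 2-nitrophenyl on a double-bonded chain carbon bound to a double-bonded ring carbon gives a number 0.22 log units higher from compound 1 to compound 3 (within the scatter), the first measured step. Both groups hold the same atoms and the same counts, and the trimethoxyphenyl side of the shared core is identical in the two compounds, so this pair isolates the two nitrophenyl groups at this place; at this scale the read-out does not separate them. No supporting measurement is available to explain this outcome.

From the compounds shown here alone, what stays open is whether any replacement of the nitro group on this phenyl ring, such as an amine or a carboxylic acid, would give a step beyond the scatter on the core of compound 1. Also open, going by these compounds, is whether the same exchange of 2-nitrophenyl for 4-nitrophenyl would give a similar step with a group other than trimethoxyphenyl, such as a plain phenyl or a longer alkyl chain, on the other side of the core.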